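The source may report more compounds than this note shows. Statements on the series, on what has been measured and on what is new or still open speak of the compounds shown alone.

Four compounds share one core, and they differ only in the amine-bearing group attached to the carbonyl-bearing side chain. Compound 1 `CNCC(=O)N1N=C(c2cc3ccccc3oc2=O)CC1c1ccccc1` gives 2300 nM in a functional assay on PC-3 cells (Homo sapiens) for cytotoxicity, read by MTT assay, with a stated time of 48 h; on this read-out lower numbers stand for stronger inhibition and higher numbers for weaker inhibition. Compound 2 `CC(C)CNCC(=O)N1N=C(c2cc3ccccc3oc2=O)CC1c1ccccc1` gives 1920 nM in this assay. Compound 3 `CC1CC(C)CN(CC(=O)N2N=C(c3cc4ccccc4oc3=O)CC2c2ccccc2)C1` gives "not active" (no number reported) in this assay, so no single number places it, and it can only be said to sit weaker than the two numbered compounds. Compound 4 `NC(=O)C1CCN(CC(=O)N2N=C(c3cc4ccccc4oc3=O)CC2c2ccccc2)CC1` is not yet measured in this assay.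

The change from compound 3 to compound 4 is 4-carbamoylpiperidin-1-yl in place of 3,5-dimethylpiperidin-1-yl on a saturated chain carbon bound to a carbonyl carbon. For the measured compounds named here, the only measured step that also touches the amine region is a 1.2-fold lower number from compound 1 to compound 2 (0.08 log units; within the scatter), and it stays within the scatter, which suggests that changes on the amine nitrogen need not move the read-out much. Yet compound 3, carrying a ring on that nitrogen, lost activity altogether, while compounds 1 and 2, carrying open chains, kept it. Compound 4 keeps a ring on the nitrogen, so it is expected to land between these outcomes, with a sizeable chance that only a limit is reported. For compound 4 the estimate in this assay is 6000 nM, with a range from 1500 nM to 30000 nM.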

Compound 4, half-maximal inhibitory concentration: 8310 nM
For compound 4 the middle estimate is 1.4-fold (0.14 log units) below the measured one; measured number inside the range.
By their numbers in this assay, from the lowest: compounds 2 and 1 (each within the scatter of the next); then compound 4.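

In this assay a ring on this saturated chain carbon does not by itself end activity: compound 4, with 4-carbamoylpiperidin-1-yl, gives a measured number, while compound 3, with 3,5-dimethylpiperidin-1-yl, gives none, so the step between these two cannot be read as a size. Replacing the open-chain amines with this ring still costs activity, with a 4.3-fold higher number from compound 2 to compound 4 (0.64 log units; beyond the scatter) and a 3.6-fold higher number from compound 1 to compound 4 (0.56 log units; beyond the scatter) as two modest steps that both lie beyond the usual scatter. Nothing measured here explains these differences.

The compounds shown leave open whether the carbamoyl group is what separates compound 4 from compound 3. A plain piperidin-1-yl, a morpholin-4-yl, or a piperidine ring carrying a carboxylic acid could help to settle this.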